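Thiophene isomer swap on the shared core

The source may hold more compounds than are shown below. What is called first, only, known or untested is meant among the compounds shown, and "the series" means these compounds.

Measured so far in a functional assay on RPTEC cells (Homo sapiens) for antiproliferative activity; a lower number here means a stronger inhibitor of growth, a higher number a weaker inhibitor of growth
compound 1 (`c1ccc(-c2cc(-c3ccsc3)cc(-c3ccccn3)n2)nc1`) gives 0.0047 ug/mL
compound 2 (`c1ccc(-c2cc(-c3ccsc3)cc(-c3cccnc3)n2)nc1`) gives 0.31 ug/mL

Compound 1 holds the lower of the two numbers. Compound 3 (`c1ccc(-c2cc(-c3cccs3)cc(-c3ccccn3)n2)nc1`) differs from it by thiophen-2-yl in place of thiophen-3-yl on an aromatic carbon. Among the compounds with values here, the only measured step (a 66-fold higher number from compound 1 to compound 2 (1.82 log units; beyond the scatter)) is large, yet it swaps pyridin-3-yl for pyridin-2-yl and leaves thiophen-3-yl untouched, so it does not size this change. Within the data shown here, no measured step covers the thiophene swap itself. A much smaller move is expected in this assay, toward a higher number and perhaps not beyond the scatter (a 1.9-fold higher number from compound 1 to compound 3 (0.28 log units; within the scatter)). The estimated value for compound 3 is 0.009 ug/mL (expected range 0.002 ug/mL to 0.05 ug/mL).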

Compound 3, concentration for 50% growth inhibition: 0.0016 ug/mL
The estimate for compound 3 lay 5.6-fold (0.75 log units) above the measured number, outside the stated range (below it).
By their numbers in this assay, from the lowest: compound 3; then compound 1; then compound 2.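

In this assay, the attachment of the thiophene opposite the ring nitrogen matters on its own: thiophen-2-yl in place of thiophen-3-yl gives a 2.9-fold lower number from compound 1 to compound 3 (0.47 log units; beyond the scatter) with the same atoms and the same counts. The earlier step, a 66-fold higher number from compound 1 to compound 2 (1.82 log units; beyond the scatter), showed sensitivity only at the pyridine, and this one, beyond the scatter, runs toward a lower number. Nothing measured here bears on the origin of this difference.

On these data alone, whether thiophen-2-yl keeps its edge alongside pyridin-3-yl remains open. So does the response of this position to an amine or a longer alkyl chain.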